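Epimer at the hydroxymethyl carbon in a dichloro lactam series

The compounds below may be only part of what the source reports. "The series", "measured", "known", "first", "only" and "open" are said of these compounds alone.

Measured compounds:
compound 1, `Cc1cc(C)c(CN2CCc3c(Cl)cc([C@@H](CO)[C@@H]4CCCO4)c(Cl)c3C2=O)c(=O)[nH]1`, 1570 nM
compound 2, `COC(c1cc(Cl)c2c(c1Cl)C(=O)N(Cc1c(C)cc(C)[nH]c1=O)CC2)C1CCOCC1`, 1460 nM; 9 nM (2 entries)
compound 3, `COC(c1cc(Cl)c2c(c1Cl)C(=O)N(Cc1c(C)cc(C)[nH]c1=O)CC2)C1CCN(C(C)=O)CC1`, 2000 nM; 11 nM (2 entries)

The account concerns an assay on cells for inhibition of histone-lysine N-methyltransferase EZH2 (Homo sapiens), read by ELISA, with a stated time of 72 h (a higher number here means a weaker inhibitor, a lower number a stronger inhibitor), and follows one change from compound 1 to compound 4. Going by the values given here, compound 1 is the only compound of the three with a single number in this assay, 1570 nM. Compound 2 and compound 3 each carry more than one entry: the several entries of compound 2 in this assay, 1460 nM; 9 nM (2 entries) and (the several entries of compound 3 in this assay, 2000 nM; 11 nM (2 entries)). Those entries span a very wide range on the same shared core, so the scaffold is capable of both weak and strong inhibition in this assay, and compound 1 sits at the weak end of what has been seen.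

Compound 4 is `Cc1cc(C)c(CN2CCc3c(Cl)cc([C@H](CO)[C@@H]4CCCO4)c(Cl)c3C2=O)c(=O)[nH]1`. It differs from compound 1 only in configuration: the two compounds have the same atoms and bonds and differ only in configuration as drawn: 1 of 2 stereo elements differ; a stereocentre at a saturated chain carbon is drawn S in compound 1 and R in compound 4. Because the entries of compound 2 the several entries of compound 2 in this assay, 1460 nM; 9 nM (2 entries) and of compound 3 the several entries of compound 3 in this assay, 2000 nM; 11 nM (2 entries) show that this core can reach strong inhibition, a change of configuration at the stereocentre is plausibly one that moves compound 4 well beyond the scatter, toward the stronger side. The size of the expected step is uncertain, with a wide range.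

For compound 4 the expected step is a 39-fold lower number from compound 1 to compound 4 (1.59 log units; beyond the scatter), and the estimate for compound 4 in this assay is 40 nM, with a range from 8 nM to 600 nM.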

Compound 4, half-maximal inhibitory concentration: 41 nM
For compound 4 the middle estimate is 1.0-fold (0.01 log units) below the measured one; the range from low to high includes it.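

In this assay, turning the stereocentre at the saturated chain carbon from S to R gives a 38-fold lower number from compound 1 to compound 4 (1.58 log units; beyond the scatter), with no atom or bond entering or leaving. The whole of this large step can be laid to that one carbon because nothing else separates the pair: the fact that compounds 1 and 4 differ only in the configuration as drawn. Going by these compounds alone, the earlier compounds showed only that the shared core can give both weak and strong numbers, without tying that spread to any one place: the several entries of compound 2 in this assay, 1460 nM; 9 nM (2 entries) and (the several entries of compound 3 in this assay, 2000 nM; 11 nM (2 entries)).

From the compounds shown here alone, the second stereo element is drawn the same in compound 1 and compound 4, and what happens when it is inverted, alone or together with the first, remains open. Also open is whether the R configuration keeps its advantage when the hydroxyl group gives way to an amine or a carboxylic acid, or when the hydroxymethyl group gives way to a longer chain, and the compounds shown do not settle what lies behind the far-apart entries of compound 2 and compound 3.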